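Anilino to methylamino step in a cytotoxicity series

The compounds below may be only part of what the source reports. "The series", "measured", "known", "first", "only" and "open" are said of these compounds alone.

Measured in an ADME assay on TERT-RPE1 cells (Homo sapiens) for cytotoxicity, read by resazurin assay, with a stated time of 48 h; on this read-out lower numbers stand for stronger inhibition and higher numbers for weaker inhibition:
compound 1, `CCOc1ccc(NC(=O)c2c(N)n[nH]c2NC)cc1`: > 100000 nM, a limit of the assay
compound 2, `CCOc1ccc(NC(=O)c2c(N)n[nH]c2Nc2ccccc2)cc1`: 67800 nM
compound 3, `CCOc1ccc(NC(=O)/C(C#N)=C(\Nc2ccccc2)SC)cc1`: > 100000 nM, a limit of the assay

Compound 2 and compound 1 share one core and differ by methyl in place of phenyl on a nitrogen on an aromatic ring; this gives an at least 1.4-fold higher number from compound 2 to compound 1 (0.16 log units; that floor lies within the scatter). Compound 3 carries a different core; the difference between the two cores is not broken down here. Compound 4, `CCOc1ccc(NC(=O)/C(C#N)=C(\NC)SC)cc1`, differs from compound 3 by methyl in place of phenyl on an amine nitrogen. The surroundings of the change are not the same: in compound 2 the nitrogen sits on an aromatic ring with an aromatic carbon as other neighbour, in compound 3 it is an amine nitrogen whose other neighbour is a double-bonded chain carbon, so this is the same kind of change, not the same one. In this assay compound 3 sits at a limit of the assay. For compound 4 the expected step is a step that the limit leaves unreadable from compound 3 to compound 4, set beside the earlier one; it rests on the limit of > 100000 nM in this assay, at which 2 of the 3 values shown sit, and on the small size of an at least 1.4-fold higher number from compound 2 to compound 1 (0.16 log units; that floor lies within the scatter). Compound 4 is expected to give 150000 nM, most likely reported again only as a limit.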

Compound 4, half-maximal inhibitory concentration: > 100000 nM
Compound 4: a limit, no number; the forecaster's own chance of this, stated with the estimate: 85%; the middle value is on the limit's open side.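

Compound 3 and compound 4 both stand only as limits in this assay, so no step between them can be read: the limit of > 100000 nM in this assay, at which 3 of the 4 values shown sit.

The compounds shown leave open whether anilino to methylamino changes this read-out at all on the core of compound 3.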